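Working notes: furan-2-yl to phenyl, compound 3 to compound 4

The compounds below may be only part of what the source reports. "The series", "measured", "known", "first", "only" and "open" are said of these compounds alone.

Measured in a functional assay on MCF7 cells (Homo sapiens) for cytotoxicity, read by MTT assay, with a stated time of 72 h; on this read-out higher numbers stand for weaker inhibition and lower numbers for stronger inhibition:
compound 1 `CNC(=O)c1cc(Oc2ccc(C(=O)/C=C/c3ccc(C#N)cc3)cc2)ccn1` gives 9520 nM
compound 2 `CNC(=O)c1cc(Oc2ccc(C(=O)/C=C/c3ccc(F)cc3)cc2)ccn1` gives 28500 nM
compound 3 `CNC(=O)c1cc(Oc2ccc(C(=O)/C=C/c3ccco3)cc2)ccn1` gives "not determined" (no result reported), that is, no reported result

For the measured compounds named here, compound 3 therefore stands nowhere on the numbers; only compounds 1 and 2 carry values, and the one measured step is a 3.0-fold higher number from compound 1 to compound 2 (0.48 log units; beyond the scatter). Compound 4 `CNC(=O)c1cc(Oc2ccc(C(=O)/C=C/c3ccccc3)cc2)ccn1` differs from compound 3 in one place: phenyl in place of furan-2-yl on a double-bonded chain carbon bound to a double-bonded chain carbon. Going by the values given here, no measured step covers a change of this kind, since the step from compound 1 to compound 2 swaps one substituent on an aromatic carbon and never touches the ring attached to the double-bonded chain carbon. What the two measured compounds show is that the shared core with a six-membered aromatic ring at that position sits in a narrow span, the difference between them being modest. Compound 4, carrying an unsubstituted phenyl, is expected to land near that span rather than far from it, in either direction. Compound 4 is estimated at 20000 nM, with a range from 7000 nM to 60000 nM.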

Compound 4, half-maximal inhibitory concentration: 5960 nM
For compound 4 the middle estimate is 3.4-fold (0.53 log units) above the measured one; measured number below the stated range.
By their numbers in this assay, from the lowest: compounds 4 and 1 (each within the scatter of the next); then compound 2.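

In this assay the change from furan-2-yl to phenyl cannot be read, as compound 3 has no reported result, so the new information concerns the aromatic carbon that carries the substituent. With the unsubstituted phenyl as reference, hydrogen in place of fluoro gives a 4.8-fold lower number from compound 2 to compound 4 (0.68 log units; beyond the scatter) and hydrogen in place of cyano gives a 1.6-fold lower number from compound 1 to compound 4 (0.20 log units; within the scatter) so among these three compounds only the fluoro compound stands apart, while the nitrile and the bare phenyl are not separated. Nothing available explains why fluoro stands apart from the other two.

On these data alone, how a five-membered aromatic ring compares with phenyl at the double-bonded chain carbon remains open. So does the reading of an amine, a carboxylic acid or a methoxy group on that aromatic carbon.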